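The compounds below may be only part of what the source reports. "The series", "measured", "known", "first", "only" and "open" are said of these compounds alone.

Measured in a functional assay on HT-29 cells (Homo sapiens) for inhibition, read by sulforhodamine B assay, with a stated time of 48 h; a lower number here means a stronger inhibitor of growth, a higher number a weaker inhibitor of growth:
- compound 1 `CCOC(=O)c1nn(-c2ccc(Cl)cc2)c(-c2ccc(C)cc2)c1CNC(C)(C)C` gives 106000 nM; > 542000 nM (2 entries)
- compound 2 `CC(C)(C)NCc1c(C(=O)O)nn(-c2ccc(Cl)cc2)c1-c1ccc(F)cc1` gives > 623000 nM (a limit)
- compound 3 `CC(C)(C)NCc1c(C(=O)O)nn(-c2ccc(Cl)cc2)c1-c1ccc(Br)cc1` gives > 542000 nM (a limit)

Compound 3 thus stands only at a limit, > 542000 nM, with no number to start from. Compound 4 `Cc1ccc(-c2c(CNC(C)(C)C)c(C(=O)O)nn2-c2ccc(Cl)cc2)cc1` differs from it by methyl in place of bromo on an aromatic carbon. For the measured compounds named here, the one measured step that bears on this is a step that the two limits leave unreadable from compound 2 to compound 3, which gives no size. Compound 1 also carries the 4-methylphenyl group, and its record is the several entries of compound 1 in this assay, 106000 nM; > 542000 nM (2 entries). No shift beyond the scatter is therefore expected in this assay, in either direction. The expected step is a step that the limit leaves unreadable from compound 3 to compound 4. For compound 4 the estimate is 600000 nM, with an expected range of 200000 nM to 700000 nM.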

Compound 4, concentration for 50% growth inhibition: > 629000 nM
Compound 4: a limit, no number; the forecaster's own chance of this, stated with the estimate: 80%; middle value at least 1.0-fold (0.02 log units) from the limit.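

In this assay compound 4 gives > 629000 nM, a limit, so its steps from compound 2 and from compound 3, both also limits, cannot be read. From the compounds shown here alone, whether 4-bromophenyl to 4-methylphenyl shifts growth inhibition at all stays open.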